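From benzyl to 4-methylphenyl on the aromatic nitrogen

The source may hold more compounds than are shown below. What is called first, only, known or untested is meant among the compounds shown, and "the series" means these compounds.

Compound 1 (`CCCCn1ccnc1-c1cc(OC)c(OC)c(OC)c1`) in a functional assay on MDA-MB-231 cells (Homo sapiens) for antiproliferative activity, read by MTT assay, with a stated time of 72 h; on this read-out lower numbers stand for stronger inhibition and higher numbers for weaker inhibition: 70400 nM
Compound 2 (`COc1cc(-c2nccn2CC(C)C)cc(OC)c1OC`), a limit only: > 100000 nM
Compound 3 (`COc1cc(-c2nccn2Cc2ccccc2)cc(OC)c1OC`), a limit only: > 100000 nM
Compound 4 (`COc1cc(-c2nccn2-c2ccc(C)cc2)cc(OC)c1OC`): not yet measured

At the limit of > 100000 nM in this assay, at which 2 of the 3 values shown sit, compound 3 has only a limit and no number. Compound 4 carries 4-methylphenyl in place of benzyl on an aromatic nitrogen. The nearest evidence is an at least 1.4-fold higher number from compound 1 to compound 3 (0.15 log units; that floor lies within the scatter) and an at least 1.4-fold higher number from compound 1 to compound 2 (0.15 log units; that floor lies within the scatter) with both floors within the scatter, while a step that the two limits leave unreadable from compound 2 to compound 3 cannot be read. Going by the values given here, no measured step places a ring directly on that nitrogen, so no change beyond the scatter is expected, and the estimated step is an at least 1.4-fold lower number from compound 3 to compound 4 (0.15 log units; that floor lies within the scatter) in this assay with no firm direction. Compound 4 is estimated at 70000 nM (range 15000 nM to 140000 nM) and may well return only a limit.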

Compound 4, half-maximal inhibitory concentration: 4100 nM
Estimate against measurement, compound 4: 17-fold (1.23 log units) above; measured number below the stated range.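

In this assay, going by these compounds alone, 4-methylphenyl set directly on the aromatic nitrogen gives a change beyond the scatter, which no step among the other compounds showed: an at least 24-fold lower number from compound 3 to compound 4 (1.38 log units; beyond the scatter), with benzyl leaving and the heavy-atom count unchanged. The same holds against the saturated chains, with an at least 24-fold lower number from compound 2 to compound 4 (1.38 log units; beyond the scatter) and a 17-fold lower number from compound 1 to compound 4 (1.23 log units; beyond the scatter). Compound 2 and compound 3 stand at a limit, so the steps from them are floors only: the limit of > 100000 nM in this assay, at which 2 of the 4 values shown sit.

Open, from the compounds shown here alone, is whether the directly attached ring alone accounts for the change or its methyl contributes. Phenyl, 4-methoxyphenyl or 4-chlorophenyl on that nitrogen would test this.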